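The compounds below may be only part of what the source reports. "The series", "measured", "known", "first", "only" and "open" are said of these compounds alone.

Compound 1 (`COC(=O)C1=C(C)N=C(C)/C(=C(\O)OC)C1c1cccc(N(C)C)c1`) 891 nM
Compound 2 (`COC(=O)C1=C(C)N=C(C)/C(=C(\O)OC)C1c1ccccc1C#N`) 15.9 nM
Compound 3 (`COC(=O)C1=C(C)N=C(C)/C(=C(\O)OC)C1c1cccc(Cl)c1Cl`) 19.1 nM

In a functional assay (muscle tissue) with Cavia porcellus as the target (a lower number here means that less compound is needed, a higher number that more compound is needed for the effect), compound 3 gives 19.1 nM and sits within the scatter of compound 2, while compound 1 shows a far higher number. The change to compound 4 (`COC(=O)C1=C(C)N=C(C)/C(=C(\O)OC)C1c1cccc(C#N)c1`) is 3-cyanophenyl in place of 2,3-dichlorophenyl on a saturated ring carbon and puts 3-cyanophenyl in place of 2,3-dichlorophenyl on a saturated ring carbon. Among the compounds with values here, the one measured step that bears on it is a 1.2-fold higher number from compound 2 to compound 3 (0.08 log units; within the scatter) and it stays small. Within the data shown here, no measured step isolates the 3-cyanophenyl group, and compound 1 at 891 nM shows that numbers can lie much higher. A modest rise in this assay is therefore expected, not clearly beyond the scatter. The estimated change is a 1.6-fold higher number from compound 3 to compound 4 (0.20 log units; within the scatter) as a working figure. For compound 4 the expected value is 30 nM with an estimated range from 8 nM to 120 nM.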

Compound 4, half-maximal effective concentration: 34.7 nM
Compound 4: middle estimate off by 1.2-fold (0.06 log units), on the low side, and the stated range covers the measured number.
By their numbers in this assay, from the lowest: compounds 2, 3 and 4 (each within the scatter of the next, the first and the last beyond it); then compound 1.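

In this assay, 3-cyanophenyl in place of 2-cyanophenyl is a modest step (a 2.2-fold higher number from compound 2 to compound 4 (0.34 log units; beyond the scatter)), so the two cyanophenyl groups are just distinguishable. Cyano in place of dimethylamino is a large step (a 26-fold lower number from compound 1 to compound 4 (1.41 log units; beyond the scatter)), whereas 3-cyanophenyl in place of 2,3-dichlorophenyl stays small (a 1.8-fold higher number from compound 3 to compound 4 (0.26 log units; within the scatter)). Nothing available gives a reason for these differences.

As far as these compounds go, whether a primary amine or a carboxylic acid on this phenyl ring would fall near compound 1 or near compound 4 stays open. The same holds for unsubstituted phenyl.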